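Benzoxazole to benzimidazole series: methylbenzyl isomer swap

The compounds below may be only part of what the source reports. "The series", "measured", "known", "first", "only" and "open" are said of these compounds alone.

Measured so far:
- compound 1, `O=C(O)[C@H]1CC[C@@H](Oc2ccc3oc(-c4ccccc4)nc3c2)CC1`: 4400 nM
- compound 2, `Cc1cccc(Cc2nc3cc(O[C@H]4CC[C@@H](C(=O)O)CC4)ccc3n2C)c1`: 42 nM
- compound 3, `Cc1cccc(Cc2nc3ccc(O[C@H]4CC[C@@H](C(=O)O)CC4)cc3n2C)c1`: > 200000 nM

All numbers come from an assay on isolated protein for inhibition of Long-chain-fatty-acid--CoA ligase 1 (Homo sapiens), read by mass spectrometry, with a stated time of 90 min, in the presence of a further agent that is not named here; a higher number here means a weaker inhibitor, a lower number a stronger inhibitor. Compound 1 gives 4400 nM, and compound 2 gives 42 nM, which is the lowest of the two numbers shown and sits a long way from compound 1, beyond the scatter. Among the measured compounds shown here, compound 3 returns only a limit, > 200000 nM, and is not a number; the same applies to the limit of > 200000 nM in this assay, at which 1 of the 3 values shown sits, which marks the one value of the three that sits at this limit.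

The next compound, compound 4, is `Cc1ccccc1Cc1nc2cc(O[C@H]3CC[C@@H](C(=O)O)CC3)ccc2n1C`. It keeps the core and the carboxylic acid side of compound 2 and differs only in the methyl position of the benzyl group: 2-methylphenyl in place of 3-methylphenyl on a saturated chain carbon bound to an aromatic carbon. For the measured compounds named here, nothing measured speaks to this change directly, so no step of the same kind is available for comparison. Moving a methyl around a ring that is not otherwise changed is expected to shift the number little, most likely within the scatter, with a slight loss the more probable direction if any. The expected step of a 1.9-fold higher number from compound 2 to compound 4 (0.28 log units; within the scatter) is therefore small. Compound 4 is estimated at 80 nM, with a range from 20 nM to 400 nM.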

Compound 4, half-maximal inhibitory concentration: 7800 nM
Beside the measured number, compound 4's estimate is 98-fold (1.99 log units) below it, outside the stated range (above it).
By their numbers in this assay, from the lowest: compound 2; then compounds 1 and 4 (each within the scatter of the next). At a limit, above all of these: compound 3.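

In this assay the placing of the methyl on the benzyl group proves decisive: 2-methylphenyl in place of 3-methylphenyl, on a saturated chain carbon bound to an aromatic carbon, gives a 190-fold higher number from compound 2 to compound 4 (2.27 log units; beyond the scatter), although the two compounds have the same atoms, joined differently. Among the compounds shown here, none of the earlier compounds formed a pair differing at this place, so this is the first direct sign that the series is sensitive here, and it shows that the methyl position alone can change the number by far more than the scatter. Nothing measured here gives a cause for this step.

This reading rests on a single pair, so it cannot yet be said whether 3-methylphenyl is favourable in itself or 2-methylphenyl is unfavourable, a question that an unsubstituted benzyl group would bear on. Also open, from the compounds shown here alone, is whether a methoxy group or a chlorine in place of the methyl would follow the same pattern, and whether the step would hold on a different core.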